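The compounds below may be only part of what the source reports. "The series", "measured", "known", "first", "only" and "open" are said of these compounds alone.

Compound 1 `Cc1ccc(S(=O)(=O)N2CC[C@@H](Cl)C[C@@H]2C2CCCCC2)cc1` and compound 2 `Cc1ccc(S(=O)(=O)N2CC[C@@H](Cl)C[C@@H]2c2ccccc2)cc1` share one saturated core and differ in a single group. In a functional assay on A2780 cells (Homo sapiens) for antiproliferative activity, read by sulforhodamine B assay, with a stated time of 48 h (a lower number here means a stronger inhibitor of growth, a higher number a weaker inhibitor of growth), compound 1 gives 72000 nM. For compound 2 the result in this assay is a limit of the assay, > 100000 nM. The change, (phenyl in place of cyclohexyl on a saturated ring carbon), thus gave an at least 1.3-fold higher number from compound 1 to compound 2 (0.14 log units; that floor lies within the scatter), its true size bounded only by the limit of > 100000 nM in this assay, at which 1 of the 3 values shown sits. Compound 3 `Cc1ccc(S(=O)(=O)N2CCC(Cl)=CC2C2CCCCC2)cc1` carries the same cyclohexyl group on a core with a double bond; how its core differs from that of compound 1 is not broken down here. In this assay compound 3 gives 39000 nM, and its gap to compound 1 lies within the scatter. Compound 4 `Cc1ccc(S(=O)(=O)N2CCC(Cl)=CC2c2ccccc2)cc1` is not yet measured; it stands to compound 3 as compound 2 stands to compound 1, the change being (phenyl in place of cyclohexyl on a saturated ring carbon), the same change at the same place. For compound 4 the expected step is a 2.3-fold higher number from compound 3 to compound 4 (0.36 log units; beyond the scatter), resting on an at least 1.3-fold higher number from compound 1 to compound 2 (0.14 log units; that floor lies within the scatter), which is itself only a floor. The estimate for compound 4 is 90000 nM, between 40000 nM and 200000 nM, with a real chance that only a limit is returned.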

Compound 4, concentration for 50% growth inhibition: 17000 nM
Estimate against measurement, compound 4: 5.3-fold (0.72 log units) above, outside the stated range (below it).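

On the core with the double bond, phenyl in place of cyclohexyl gave a 2.3-fold lower number from compound 3 to compound 4 (0.36 log units; beyond the scatter) in this assay. The change therefore did not carry over unchanged from one core to the other, and the two steps run in opposite directions: the same change on two cores in this assay, an at least 1.3-fold higher number (0.14 log units; that floor lies within the scatter) from compound 1 to compound 2 and a 2.3-fold lower number (0.36 log units; beyond the scatter) from compound 3 to compound 4, at least 3.1-fold (0.50 log units) apart, beyond the scatter of two such steps Compound 2 stands at a limit of the assay, so the step on the saturated core is known only as a floor, and these two pairs show neither why the cores part nor how the change would behave on any further core: the limit of > 100000 nM in this assay, at which 1 of the 4 values shown sits.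

The compounds shown leave open whether a pyridyl ring or a simple methyl group in this place, on the saturated ring carbon next to the ring nitrogen, would also separate the two cores. They also leave open whether the difference between the cores would persist with a bromo or a hydroxyl group in place of the chloro group.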